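A few compounds are considered here, and "the series" means these few. Any claim that something is new, unique, unknown or untested is made for them only; others in the source may bear on it.

Measured in an ADME assay on RAW264.7 cells (Mus musculus) for cytotoxicity, read by MTT assay, with a stated time of 24 h, tested at 10 ug/mL; a higher number here means a weaker effect of the compound at the concentration tested, a lower number a stronger effect:

compound 1 `COc1ccc(/C=C/C(=O)c2ccc(OC)c(OC)c2)cc1` — 73.9%
compound 2 `COc1ccc(C(=O)/C=C/c2ccc(OC)c(OC)c2)c(O)c1` — 70%
compound 3 `COc1ccc(C(=O)/C=C/c2ccc(OC)c(OC)c2OC)c(O)c1` — 75.3%

All three numbers lie within the usual scatter of one another: compound 3 is not told apart from compound 1, nor from compound 2. Among the measured compounds shown here, the one single-point step among them, a number 5.3 percentage points higher from compound 2 to compound 3 (within the scatter), is a methoxy in place of hydrogen on an aromatic carbon, and it stayed within the scatter.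

Compound 4 `COc1ccc(C(=O)/C=C/c2cccc(OC)c2OC)c(O)c1` has not been measured. Against compound 3 the change is hydrogen in place of methoxy on an aromatic carbon. For the measured compounds named here, this is the same kind of change as the measured step, taken in the opposite sense and at another aromatic carbon, so the step from compound 2 to compound 3 is the only guide, and it was small. Nothing in the three values suggests that adding or removing one methoxy moves this assay beyond its scatter, so compound 4 is expected to land close to compound 3, with the expected step of a number 2.3 percentage points lower from compound 3 to compound 4 (within the scatter) lying within the scatter in either direction. The estimate for compound 4 is therefore 73%, with a range from 62% to 84%.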

Compound 4, a percentage reported as activity, at one concentration (the size of the read-out at that concentration, not a potency): 60.3%
Beside the measured number, compound 4's estimate is 12.7 percentage points above it; measured number outside the range, below it.
By their numbers in this assay, from the lowest: compounds 4, 2, 1 and 3 (each within the scatter of the next, the first and the last beyond it).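

Hydrogen in place of methoxy on this aromatic carbon, para to a large group and ortho to a methoxy group, gives a lower number in this assay (a number 15 percentage points lower from compound 3 to compound 4 (beyond the scatter)), which means a stronger effect at the concentration tested, so this methoxy of compound 3 matters to the read-out. Among the compounds shown here, the only earlier single-place step (a number 5.3 percentage points higher from compound 2 to compound 3 (within the scatter)) involved a methoxy at another aromatic carbon and stayed within the scatter, so among compounds 2, 3 and 4 a methoxy change does not read the same at each carbon of this ring. No measurement at hand accounts for the difference between the two carbons.

The compounds shown leave open whether the step follows from the loss of the methoxy as such or would also appear with another group on this carbon, such as a hydroxyl, a fluorine atom, an amine or a longer ethoxy chain. For the compounds shown here, they also leave open whether the same change would give a step of this size on a partner lacking the other two methoxy groups of compound 3, since this carbon has been read in only one pair.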